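Changing the Aryl Group on the Amide Nitrogen

The source may report more compounds than this note shows. Statements on the series, on what has been measured and on what is new or still open speak of the compounds shown alone.

Measured so far:
compound 1, `O=C(CSc1nc(Nc2ccccc2)c2ccccc2n1)Nc1ccccc1Cl`, gives 14600 nM in a functional assay on PC-3 cells (Homo sapiens) for inhibition, read by MTT assay, with a stated time of 72 h; on this read-out lower numbers stand for stronger inhibition and higher numbers for weaker inhibition
compound 2, `O=C(CSc1nc(Nc2ccccc2)c2ccccc2n1)Nc1cccc(Br)c1`, gives 11400 nM in this assay
compound 3, `O=C(CSc1nc(Nc2ccccc2)c2ccccc2n1)Nc1ccc(F)cc1`, gives 9560 nM in this assay

Compound 2 holds the second highest of the three numbers: its nearest neighbour is compound 3 at a 1.2-fold lower number from compound 2 to compound 3 (0.08 log units; within the scatter), its furthest compound 1 at a 1.3-fold lower number from compound 1 to compound 2 (0.11 log units; within the scatter). Compound 4, `O=C(CSc1nc(Nc2ccccc2)c2ccccc2n1)Nc1ccc(Cl)c(Cl)c1`, differs from compound 2 by 3,4-dichlorophenyl in place of 3-bromophenyl on an amide-type nitrogen. Every measured step alters this same aryl group on the amide-type nitrogen, and none left the scatter: a 1.3-fold lower number from compound 1 to compound 2 (0.11 log units; within the scatter), a 1.5-fold lower number from compound 1 to compound 3 (0.18 log units; within the scatter) and a 1.2-fold lower number from compound 2 to compound 3 (0.08 log units; within the scatter). No step beyond the scatter is therefore expected in this assay. Compound 4 is estimated at 10500 nM, with a range of 4500 nM to 25000 nM. The expected step of a 1.1-fold lower number from compound 2 to compound 4 (0.04 log units; within the scatter) thus stays within the scatter.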

Compound 4, half-maximal inhibitory concentration: 12100 nM
For compound 4 the middle estimate is 1.2-fold (0.06 log units) below the measured one, within the range that was stated.
By their numbers in this assay, from the lowest: compounds 3, 2, 4 and 1 (each within the scatter of the next).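

Compound 4 shows that this position on the amide-type nitrogen also tolerates an aryl group carrying two chlorine atoms, and 3,4-dichlorophenyl stays within the scatter of all three singly halogenated aryl groups in this assay (a 1.1-fold higher number from compound 2 to compound 4 (0.03 log units; within the scatter); a 1.3-fold higher number from compound 3 to compound 4 (0.10 log units; within the scatter); a 1.2-fold lower number from compound 1 to compound 4 (0.08 log units; within the scatter)). All four halogenated aryl groups thus remain within the scatter of each other in this assay. Nothing available bears on this result.

The compounds shown leave open whether an amine, a carboxylic acid or a methoxy group on this aryl ring would produce a step beyond the scatter. They also leave open how a non-aromatic group such as cyclohexyl would behave on this nitrogen.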